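The compounds below may be only part of what the source reports. "The series", "measured", "known", "first", "only" and "open" are said of these compounds alone.

In a functional assay on HeLa cells (Homo sapiens) for cytotoxicity, read by WST assay, with a stated time of 48 h (a lower number here means a stronger inhibitor, a higher number a weaker inhibitor), compound 1 `COc1cc(C(c2ccc(O)c(OC)c2)[C@H](C)C(C)C)ccc1O` gives 16000 nM and its stereoisomer, compound 2 `COc1cc(C(c2ccc(O)c(OC)c2)[C@@H](C)C(C)C)ccc1O`, gives 19000 nM. These two values sit level at the top of the three numbers available, while compound 3 `CCCCCCCC[C@H](C(C)C)C(c1ccc(O)c(OC)c1)c1ccc(O)c(OC)c1` reads lower at 3100 nM. Compound 4 `COC[C@@H](C)[C@@H](C)C(c1ccc(O)c(OC)c1)c1ccc(O)c(OC)c1` departs from compound 2 through (2-(methoxymethyl)-1-methylpropyl in place of 1,2-dimethylpropyl on a saturated chain carbon bound to two aromatic carbons). For the measured compounds named here, two measured steps bear on this. The first is a 1.2-fold higher number from compound 1 to compound 2 (0.07 log units; within the scatter), and it rests on (the fact that compounds 1 and 2 differ only in the configuration as drawn), so the drawn configuration at that chain carbon gave no step beyond the scatter here. The second is a 5.2-fold lower number from compound 1 to compound 3 (0.71 log units; beyond the scatter), a modest step that came with a whole heptyl added to the chain. The 2-(methoxymethyl)-1-methylpropyl group of compound 4 adds far less than that heptyl, so only a small shift is expected, if any, towards the lower number. The expected move is a 1.4-fold lower number from compound 2 to compound 4 (0.13 log units; within the scatter), which is estimated to stay within the scatter. For compound 4 the estimated value is 14000 nM, with an expected range of 6000 nM to 32000 nM.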

Compound 4, half-maximal inhibitory concentration: > 100000 nM
Compound 4 was reported as a limit; the forecaster's own chance of this, stated with the estimate: 10%; middle value at least 7.1-fold (0.85 log units) from the limit.
By their numbers in this assay, from the lowest: compound 3; then compounds 1 and 2 (each within the scatter of the next). At a limit, above all of these: compound 4.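

In this assay compound 4 is reported only as a limit, > 100000 nM. For the compounds shown here, the steps at this position now run towards a higher number, an at least 5.2-fold higher number from compound 2 to compound 4 (0.72 log units; beyond the scatter) and an at least 6.2-fold higher number from compound 1 to compound 4 (0.79 log units; beyond the scatter), whereas the only earlier change there that went beyond the scatter ran the other way, a 5.2-fold lower number from compound 1 to compound 3 (0.71 log units; beyond the scatter). So lengthening the chain on this saturated carbon does not by itself give a lower number: adding heptyl did, while the 2-(methoxymethyl)-1-methylpropyl group gave a step upward.

The compounds shown leave open how far the true value of compound 4 lies past its limit, and whether the step follows the methoxy group or the second defined stereocentre. A hydroxyl, an amine or an ethyl in place of that methoxy would help to separate these readings.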